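Swapping Methoxy for Methylsulfonyl on an Amide-Type Nitrogen

The source may report more compounds than this note shows. Statements on the series, on what has been measured and on what is new or still open speak of the compounds shown alone.

Measured so far in a physicochemical assay for solubility, read by LC-MS, in phosphate buffer, measured as kinetic solubility, with a stated time of 24 h, at pH 7.4, tested at 200 uM; a higher number here means a more soluble compound, a lower number a less soluble compound
Compound 1 `Oc1c(F)cc(Cc2ccccc2)cc1F` gives 109000 nM
Compound 2 `CONC(=O)CCc1ccccc1` gives >= 200000 nM
Compound 3 `CS(=O)(=O)NC(=O)NCc1ccccc1` gives 198000 nM

Compound 2 reads >= 200000 nM here, and this is a limit of the assay, not a number. Compound 2 therefore stands at the limit of the values shown (the limit of >= 200000 nM in this assay, at which 1 of the 3 values shown sits).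

Compound 4 `CS(=O)(=O)NC(=O)CCc1ccccc1` has not yet been measured. It keeps the rest of compound 2 and carries methylsulfonyl in place of methoxy on an amide-type nitrogen. Going by the values given here, no measured pair shows this exact change, so any expectation has to lean on the neighbouring compounds. Compound 3 also carries methylsulfonyl, and compound 3 gives 198000 nM in this assay as its result. That value sits close to the limit reached by compound 2, so a large fall seems unlikely. The expected step of an at least 1.1-fold lower number from compound 2 to compound 4 (0.04 log units; that floor lies within the scatter) stays within the usual scatter, with no clear direction. The assay may well report only a limit again. The estimated value for compound 4 is 180000 nM with an expected range from 110000 nM to 200000 nM in this measurement.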

Compound 4, solubility: 200000 nM
Compound 4: the middle estimate sits 1.1-fold (0.05 log units) below what was measured; measured number inside the range.
By their numbers in this assay, from the lowest: compounds 1, 3 and 4 (each within the scatter of the next).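

In this assay, compound 4 gives 200000 nM, which shows that this amide-type nitrogen can carry methylsulfonyl, with 4 heavy atoms and 2 double bonds outside aromatic rings, and still give a reading in the same high part of the values shown. Going by these compounds alone, this is the first direct comparison of methoxy and methylsulfonyl at this position, and it can be stated only as a number no higher from compound 2 to compound 4 (the limit leaves the size open). Compound 2 stands at a limit of the assay, which is not a number, so the step has a direction but no size that can be read: the limit of >= 200000 nM in this assay, at which 1 of the 4 values shown sits.

The compounds shown leave open how far compound 2 would really stand from compound 4, and so whether swapping methoxy for methylsulfonyl changes the reading by little or by much. They also leave open what other groups would give on the same amide-type nitrogen, such as ethylsulfonyl, with its longer chain, or a group ending in a carboxylic acid or an amine, which would show how much variety this position tolerates.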